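This account rests on a few compounds, and the source may have more. Where it says the series, first, only, none or still open, it means among the compounds named here.

Measured so far:

Compound 1, `CCOC(=O)C(CCc1cccc(C(=N)N)c1)Cn1cnc2cc(C(=N)N)ccc21`: 220 nM
Compound 2, `CNS(=O)(=O)c1ccccc1-c1ccc(NC(=O)Cc2c[nH]c3ccc(C(=N)N)cc23)cc1`: 120 nM

Both numbers come from an assay on isolated protein for binding affinity to serine protease 1 (Homo sapiens); a lower number here means a stronger inhibitor, a higher number a weaker inhibitor. Of the two, compound 2 carries the lower inhibition constant, with compound 1 nearest to it; the gap between them lies within the scatter of repeated measurements, so the two compounds cannot be told apart on these numbers.

Compound 3, `CN(C)S(=O)(=O)c1ccccc1-c1ccc(NC(=O)Cc2c[nH]c3ccc(C(=N)N)cc23)cc1`, is the untested partner of compound 2. The two differ in one place only: methyl in place of hydrogen on a sulfonamide nitrogen. The rest of the molecule, including the amidine and the amide linker, is unchanged.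

Within the data shown here, no measured pair in this set shows what this kind of change does, so there is no step to lean on. The change is small, a single carbon added to the sulfonamide nitrogen, far from the amidine that both compounds share. The expectation for compound 3 is therefore a number close to that of compound 2, with no shift beyond the scatter in either direction, which as a step reads a 1.1-fold higher number from compound 2 to compound 3 (0.03 log units; within the scatter). On that basis compound 3 is estimated at 130 nM, with a plausible range from 50 nM to 350 nM.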

Compound 3, inhibition constant: 390 nM
The estimate for compound 3 lay 3.0-fold (0.48 log units) below the measured number; the whole stated range lies below it.
By their numbers in this assay, from the lowest: compounds 2, 1 and 3 (each within the scatter of the next, the first and the last beyond it).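

In this assay, the sulfonamide nitrogen proves sensitive to a small change: swapping methylsulfamoyl for dimethylsulfamoyl gives a 3.3-fold higher number from compound 2 to compound 3 (0.51 log units; beyond the scatter). The earlier compounds shown here differed in more than one place and offered no such direct comparison, whereas this pair shows that methyl in place of hydrogen on this nitrogen, a change of only 1 carbon, can weaken inhibition by a modest but readable amount while the rest of the molecule stays the same. Nothing available here explains why this weakening occurs.

This single pair cannot separate two readings: the hydrogen on the sulfonamide nitrogen may be what matters, or the added methyl may be what matters. A plain sulfamoyl group, with hydrogen in place of the methyl of compound 2, would test how far the number depends on the substitution of this nitrogen, while an ethyl group or a longer chain on the same nitrogen would show whether the number keeps moving in the same direction as the group grows.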